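The source may hold more compounds than are shown below. What is called first, only, known or untested is meant among the compounds shown, and "the series" means these compounds.

In an assay on membranes from HeLa cells for displacement of a labelled ligand from adenosine receptor A3 (Homo sapiens), read by scintillation counting, with a stated time of 180 min, tested at 1 uM (on this read-out lower numbers stand for less inhibition and higher numbers for more inhibition at the one concentration tested (going by the name of the read-out)), two compounds have been measured:

Compound 1 `CCN(CC)C(=O)C1=C(C)NC(=O)NC1c1ccco1` gives 19%.
Compound 2 `CCSC(=O)C1=C(C)NC(=O)NC1c1ccco1` gives 14%.

Compound 2 stands lowest of the two, with compound 1 nearest, though the step of a number 5 percentage points lower from compound 1 to compound 2 (within the scatter) lies within the scatter. Compound 3 `CC1=C(C(=O)SC(C)C)C(c2ccco2)NC(=O)N1` differs from compound 2 by methyl in place of hydrogen on a saturated chain carbon bound to a saturated chain carbon and a sulfur. Within the data shown here, the only measured step changed the group on the carbonyl carbon and barely moved the number, so no step beyond the scatter is expected here. Compound 3 is estimated at 15%, within 4% to 28%, an expected step of a number 1 percentage points higher from compound 2 to compound 3 (within the scatter).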

Compound 3, a percentage reported as inhibition, at one concentration (the size of the read-out at that concentration, not a potency): 1%
Beside the measured number, compound 3's estimate is 14 percentage points above it; measured number below the stated range.
By their numbers in this assay, from the lowest: compound 3; then compounds 2 and 1 (each within the scatter of the next).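

In this assay, one added methyl, turning ethylsulfanyl into isopropylsulfanyl, gives a number 13 percentage points lower from compound 2 to compound 3 (beyond the scatter), so this saturated chain carbon bound to a saturated chain carbon and a sulfur responds to a small change. Changing the whole group on the carbonyl carbon, from diethylamino to isopropylsulfanyl, gives a number 18 percentage points lower from compound 1 to compound 3 (beyond the scatter), whereas the earlier swap to ethylsulfanyl stayed within the scatter. No measurement shown gives a reason for this result. Still open, on these data alone, is whether a propyl or a tert-butyl on the sulfur would lower the number further.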